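Removing a Fluoro from the Aryl Ring of Compound 3

The compounds below may be only part of what the source reports. "The series", "measured", "known", "first", "only" and "open" are said of these compounds alone.

In an ADME assay on the whole organism (Mus musculus, strain Swiss Webster) for pharmacokinetics, read by LC-MS, at a dose of 50 mg/kg by the oral route (a lower number here means less compound in the circulation, a higher number more compound in the circulation at the dose given), compound 3 `O=C(Nc1ccc(F)c(-c2nc3ncc(-c4ccc(F)c(F)c4)cc3[nH]2)c1)N1CCCC1` gives 12000 ng.h/mL, the second highest of the three numbers: compound 1 `O=C(Nc1ccc(F)c(-c2nc3ncc(-c4cccc(F)c4)cc3[nH]2)c1)N1CCCC1` gives 15000 ng.h/mL and compound 2 `O=C(Nc1ccc(F)c(-c2nc3ncc(-c4cc(F)cc(F)c4)cc3[nH]2)c1)N1CCCC1` gives 9400 ng.h/mL. Compound 4 `O=C(Nc1ccc(F)c(-c2nc3ncc(-c4ccc(F)cc4)cc3[nH]2)c1)N1CCCC1` differs from compound 3 by hydrogen in place of fluoro on an aromatic carbon. Among the measured compounds shown here, the steps that bear on this change are those that add or move a fluoro on the same ring: a 1.3-fold lower number from compound 1 to compound 3 (0.10 log units; within the scatter), a 1.6-fold lower number from compound 1 to compound 2 (0.20 log units; within the scatter) and a 1.3-fold higher number from compound 2 to compound 3 (0.11 log units; within the scatter), all within the scatter. Taking one fluoro away is therefore expected to leave compound 4 within the scatter of compound 3, with a 1.1-fold higher number from compound 3 to compound 4 (0.03 log units; within the scatter). Compound 4 is estimated to give 13000 ng.h/mL, with a range from 7000 ng.h/mL to 24000 ng.h/mL.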

Compound 4, area under the concentration-time curve: 10200 ng.h/mL
Estimate against measurement, compound 4: 1.3-fold (0.11 log units) above; the measured number falls inside the stated range.
By their numbers in this assay, from the lowest: compounds 2, 4, 3 and 1 (each within the scatter of the next).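

In this assay, the change from 3,4-difluorophenyl to 4-fluorophenyl gives a 1.2-fold lower number from compound 3 to compound 4 (0.07 log units; within the scatter), so hydrogen and fluoro at this position read alike. Compound 4 also stays within the scatter of the other two, with a 1.1-fold higher number from compound 2 to compound 4 (0.04 log units; within the scatter) and a 1.5-fold lower number from compound 1 to compound 4 (0.17 log units; within the scatter), so all four fluoro patterns on this ring read alike. The fluoro step also reads alike in two settings: the same change on two cores in this assay, a 1.6-fold lower number (0.20 log units; within the scatter) from compound 1 to compound 2 and a 1.2-fold higher number (0.07 log units; within the scatter) from compound 4 to compound 3, 1.9-fold (0.27 log units) apart, within the scatter of two such steps.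

The compounds shown carry only hydrogen or fluoro on this ring. From the compounds shown here alone, whether a methoxy group, an amine or a nitrile at this position would move the number beyond the scatter remains open.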